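The source may hold more compounds than are shown below. What is called first, only, known or untested is meant among the compounds shown, and "the series" means these compounds.

Going by the values given here, compound 2 `CC1=C(/C=C/C(=O)/C=C/c2cccc(F)c2)C(C)(C)CCC1O` is, in a functional assay on CWR22R cells (Homo sapiens) for cytotoxicity, read by MTT assay, with a stated time of 72 h (on this read-out higher numbers stand for weaker inhibition and lower numbers for stronger inhibition), the compound with the higher of the two numbers measured so far: in this assay compound 2 gives 5600 nM. Among the compounds with values here, its only measured neighbour is compound 1 `CC1=C(/C=C/C(=O)/C=C/c2cccc(C(F)(F)F)c2)C(C)(C)CCC1O`, which in this assay gives 1700 nM. Within the data shown here, the one step connecting them, a 3.3-fold higher number from compound 1 to compound 2 (0.52 log units; beyond the scatter), is the sole measured change that bears on what comes next.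

Compound 3 `CC1=C(/C=C/C(=O)/C=C/c2cc(F)cc(C(F)(F)F)c2)C(C)(C)CCC1O` differs from compound 2 by trifluoromethyl in place of hydrogen on an aromatic carbon. This restores the trifluoromethyl group whose removal in going from compound 1 to compound 2 was accompanied by the rise recorded in this assay, while the fluoro group of compound 2 is kept. Because a 3.3-fold higher number from compound 1 to compound 2 (0.52 log units; beyond the scatter) was a modest rise, the return of that group is expected to bring a modest fall in this assay, roughly undoing it, though the retained fluoro group leaves the exact size uncertain. Compound 3 is therefore expected to give about 2000 nM in this assay, within a range of 800 nM to 5000 nM, a step of a 2.8-fold lower number from compound 2 to compound 3 (0.45 log units; beyond the scatter) expected from compound 2.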

Compound 3, half-maximal inhibitory concentration: 2400 nM
For compound 3 the middle estimate is 1.2-fold (0.08 log units) below the measured one, and the stated range covers the measured number.
By their numbers in this assay, from the lowest: compounds 1 and 3 (each within the scatter of the next); then compound 2.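

In this assay, trifluoromethyl in place of hydrogen on an aromatic carbon gives a 2.3-fold lower number from compound 2 to compound 3 (0.37 log units; beyond the scatter), so the lower number goes with this group even when the fluoro group stays in place, which the earlier swap of one group for the other could not show. Fluoro in place of hydrogen gives a 1.4-fold higher number from compound 1 to compound 3 (0.15 log units; within the scatter), so compound 1 and compound 3 cannot be told apart, and a fluoro group meta to a large group makes no readable difference here. Among these three compounds, the one without trifluoromethyl, compound 2, is the one that stands apart. Nothing available here explains these steps. As far as these compounds go, whether a chloro group, a methoxy group or a nitrile on that aromatic carbon would match trifluoromethyl stays open, as does what a carboxylic acid there would do.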